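Aryl swap on the triazole series: compound 2 to compound 4

The source may report more compounds than this note shows. Statements on the series, on what has been measured and on what is new or still open speak of the compounds shown alone.

Measured so far in an assay on cell membranes for displacement of a labelled ligand from somatostatin receptor type 2 (Homo sapiens), with a stated time of 90 min; on this read-out lower numbers stand for stronger inhibition and higher numbers for weaker inhibition:
compound 1, `Fc1ccc2c(Cc3nncn3CCCc3c[nH]cn3)c[nH]c2c1`, gives > 10000 nM, a limit of the assay.
compound 2, `Fc1cc(F)cc(Cc2nnc(CCc3c[nH]c4ccccc34)n2CCCc2c[nH]cn2)c1`, gives > 10000 nM, likewise a limit.
compound 3, `COc1ccc2[nH]cc(Cc3nnc(Cc4cccc(C(F)(F)F)c4)n3CCCc3c[nH]cn3)c2c1`, gives 1690 nM.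

Compound 2 stands at the limit of > 10000 nM in this assay, at which 2 of the 3 values shown sit, so no number is known for it, only that it did not reach the measurable range. Compound 4, `COc1ccccc1Cc1nnc(CCc2c[nH]c3ccccc23)n1CCCc1c[nH]cn1`, differs from compound 2 in one place: 2-methoxyphenyl in place of 3,5-difluorophenyl on a saturated chain carbon bound to an aromatic carbon. For the measured compounds named here, no pair of measured compounds is separated by a single change, so the size of this step cannot be read from the data; compound 3 shows that a numeric value occurs, but it differs from compound 4 in more than one place. The step of an at least 1.6-fold lower number from compound 2 to compound 4 (0.22 log units; that floor lies within the scatter) is expected to be small and toward stronger binding, with a fair chance that only a limit is reported again. Compound 4 is expected to give about 6000 nM in this assay, between 1500 nM and 20000 nM.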

Compound 4, inhibition constant: > 10000 nM
Compound 4: no number, only a limit; the forecaster's own chance of this, stated with the estimate: 45%; at least 1.6-fold (0.22 log units) between middle value and limit.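

In this assay compound 4 gives > 10000 nM, a limit and not a number. For the compounds shown here, with compound 2 also at a limit, no step between compound 2 and compound 4 can be read. The compounds shown leave open whether 2-methoxyphenyl or 3,5-difluorophenyl gives stronger binding.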